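Methylamino for Chloro on the Aryl Ring of Compound 2

A few compounds are considered here, and "the series" means these few. Any claim that something is new, unique, unknown or untested is made for them only; others in the source may bear on it.

Of the compounds shown here, three sharing one core have been measured in an assay on HEK293 cells for displacement of a labelled ligand from 5-hydroxytryptamine receptor 7 (Rattus norvegicus), read by radioligand binding; on this read-out lower numbers stand for stronger inhibition and higher numbers for weaker inhibition. Compound 1 `Cc1ccc(-c2c3c(nn2C(C)C)CCNCC3)cc1` gives 6 nM. Compound 2 `CC(C)n1nc2c(c1-c1ccc(Cl)cc1)CCNCC2` gives 9 nM, and compound 3 `CC(C)n1nc2c(c1-c1ccc(F)cc1)CCNCC2` gives 7.94 nM; 8 nM (2 entries). Of the two single numbers, compound 2 shows the higher one, yet the step of a 1.5-fold higher number from compound 1 to compound 2 (0.18 log units; within the scatter) lies within the scatter, so no order between compound 1 and compound 2 is claimed. The repeat entries of compound 3, (the several entries of compound 3 in this assay, 7.94 nM; 8 nM (2 entries)), show how closely this assay reproduces a value, and its numbers sit close to those of the other two.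

Compound 4 `CNc1ccc(-c2c3c(nn2C(C)C)CCNCC3)cc1` is not yet measured. It differs from compound 2 in one place: methylamino in place of chloro on an aromatic carbon. Among the measured compounds shown here, the only measured step at that aromatic carbon, a 1.5-fold higher number from compound 1 to compound 2 (0.18 log units; within the scatter), exchanged one small group for another without moving the number beyond the scatter. For the measured compounds named here, the methylamino group brings in a hydrogen-bond donor and acceptor that none of the measured substituents carries, so the measured steps give no direct guide to its size. Compound 4 is therefore expected to give 15 nM, within 4 nM to 60 nM. The step of a 1.7-fold higher number from compound 2 to compound 4 (0.22 log units; within the scatter) is estimated to be modest, with a wide range in either direction.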

Compound 4, inhibition constant: 40 nM
For compound 4 the middle estimate is 2.7-fold (0.43 log units) below the measured one; the range from low to high includes it.
By their numbers in this assay, from the lowest: compounds 1 and 2 (each within the scatter of the next); then compound 4.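

In this assay this aromatic carbon, para to a large group, proves sensitive to its substituent: methylamino in place of chloro gives a 4.4-fold higher number from compound 2 to compound 4 (0.65 log units; beyond the scatter), and methylamino in place of methyl gives a 6.7-fold higher number from compound 1 to compound 4 (0.82 log units; beyond the scatter). Both steps lie beyond the scatter, whereas the earlier exchange at this carbon, a 1.5-fold higher number from compound 1 to compound 2 (0.18 log units; within the scatter), stayed within it, so the position does not treat every small group alike, even though chloro and methyl could not be told apart. The size of these steps stands well clear of what repeat measurements show for this read-out: the several entries of compound 3 in this assay, 7.94 nM; 8 nM (2 entries)

What compound 4 cannot separate is whether the higher number goes with the nitrogen, with its hydrogen or with the added carbon, and a primary amine, a dimethylamino group or a methoxy group at this carbon would pull those apart. On these data alone, whether the step would keep its size with other groups elsewhere on the shared core also stays open.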